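Aminothiophene ketone series: amine substituent and adenosine receptor activity

This account rests on a few compounds, and the source may have more. Where it says the series, first, only, none or still open, it means among the compounds named here.

Measured so far:
compound 1, `Nc1scc(CN2CCN(c3cccnc3)CC2)c1C(=O)c1ccc(Cl)cc1`, -23%
compound 2, `Nc1scc(CN2CCC(c3ccc(Cl)cc3)CC2)c1C(=O)c1ccc(Cl)cc1`, -61%
compound 3, `Nc1scc(CN2CCN(c3ccc(C(F)(F)F)cc3)CC2)c1C(=O)c1cccc(C(F)(F)F)c1`, -47%

All three share the aminothiophene ketone core and differ in the saturated amine ring and the group on it. In a functional assay on CHO cells with adenosine receptor A1 (Homo sapiens) as the target, read by cAMP accumulation and immunoassay, with a stated time of 6 min, tested at 10 uM (on this read-out higher numbers stand for a weaker effect at the one concentration tested and lower numbers for a stronger effect), compound 1 gives -23%, the highest of the three numbers, so the weakest effect at the concentration tested. Compound 3 sits nearest to it, a step beyond the scatter; compound 2 lies furthest, also beyond the scatter. Among the compounds with values here, no pair among the measured compounds differs in only one place, so no single-change step is available.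

Compound 4, `Nc1scc(CN2CCN(CCCc3ccc(Cl)cc3)CC2)c1C(=O)c1ccc(Cl)cc1`, has not been measured. It departs from compound 1 as follows: 3-(4-chlorophenyl)propyl in place of pyridin-3-yl on an amine nitrogen in a ring. The change keeps the two-nitrogen ring of compound 1 but replaces the aromatic heterocycle on the ring nitrogen with a chain ending in a chlorophenyl, bringing compound 4 closer in its outer group to compound 2, which gives -61%, and to compound 3, which gives -47%.

On that basis the number for compound 4 in this assay is expected to fall below that of compound 1, with an estimated step of a number 22 percentage points lower from compound 1 to compound 4 (beyond the scatter) that lies beyond the scatter. The estimate for compound 4 is -45%, with a range from -70% to -15%.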

Compound 4, a percentage reported as activity, at one concentration (the size of the read-out at that concentration, not a potency): -76%
Beside the measured number, compound 4's estimate is 31 percentage points above it, and the stated range ends above it.
By their numbers in this assay, from the lowest: compound 4; then compound 2; then compound 3; then compound 1.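

In this assay, the substituent on the amine nitrogen of the six-membered non-aromatic ring with 2 nitrogen proves able to shift the read-out on its own: 3-(4-chlorophenyl)propyl in place of pyridin-3-yl gives a number 53 percentage points lower from compound 1 to compound 4 (beyond the scatter). The earlier compounds shown here differed from one another in more than one place, so none of their gaps could be assigned to this position, whereas here the rest of compound 1 stays unchanged. The swap alters several things together, replacing a nitrogen-containing aromatic ring with a chain-linked chlorophenyl and raising the group from 6 to 10 heavy atoms, and no measurement at hand explains the size of the step.

The compounds shown leave open whether the step follows the propyl chain, the chlorine or the loss of the ring nitrogen, a split that benzyl, 3-phenylpropyl and 3-(pyridin-3-yl)propyl on the same nitrogen would help to resolve. Going by these compounds, it also remains open whether the step holds with another group on the ketone, such as the 3-(trifluoromethyl)phenyl of compound 3, and, with one concentration per compound, how it translates into potency.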